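Methylsulfanyl for Benzylselanyl in Two Acylated Amidine Series

This account rests on a few compounds, and the source may have more. Where it says the series, first, only, none or still open, it means among the compounds named here.

Compound 2 `O=C(/N=C(/NC(=O)c1ccno1)[Se]Cc1ccccc1)c1ccno1` and compound 3 `O=C(/N=C(/NC(=O)c1cccs1)[Se]Cc1ccccc1)c1cccs1` differ in their cores, and that difference is not broken down here. In a functional assay on HT-29 cells (Homo sapiens) for cytotoxicity, read by MTT assay, with a stated time of 72 h (on this read-out higher numbers stand for weaker inhibition of growth and lower numbers for stronger inhibition of growth), compound 2 gives 6820 nM, while compound 3 gives 55100 nM. Compound 1 `CS/C(=N\C(=O)c1ccno1)NC(=O)c1ccno1` reaches only a limit in this assay, reported as > 100000 nM. The step of an at least 14-fold higher number from compound 2 to compound 1 (1.16 log units; beyond the scatter) goes with the change (a group of 2 heavy atoms (1 carbon, 1 sulfur; no ring) in place of a group of 8 heavy atoms (7 carbon, 1 selenium; one six-membered aromatic ring of carbon only), on a carbon with a double bond to nitrogen), and its size is bounded by the limit of > 100000 nM in this assay, at which 1 of the 3 values shown sits. Compound 4 `CS/C(=N\C(=O)c1cccs1)NC(=O)c1cccs1` carries the same change on the core of compound 3, namely (a group of 2 heavy atoms (1 carbon, 1 sulfur; no ring) in place of a group of 8 heavy atoms (7 carbon, 1 selenium; one six-membered aromatic ring of carbon only), on a carbon with a double bond to nitrogen). Compound 3 starts from 55100 nM, and a step of the size an at least 14-fold higher number from compound 2 to compound 1 (1.16 log units; beyond the scatter) would already pass the limit of this assay. The step expected is a 5.4-fold higher number from compound 3 to compound 4 (0.74 log units; beyond the scatter). Compound 4 is therefore estimated at 300000 nM, and a limit rather than a number is the likely report.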

Compound 4, concentration for 50% growth inhibition: 77900 nM
Beside the measured number, compound 4's estimate is 3.9-fold (0.59 log units) above it; the whole stated range lies above it.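

In this assay the change to methylsulfanyl gives a 1.4-fold higher number from compound 3 to compound 4 (0.15 log units; within the scatter), so the step does not carry over at the same size between these two cores: the same change on two cores in this assay, an at least 14-fold higher number (1.16 log units; beyond the scatter) from compound 2 to compound 1 and a 1.4-fold higher number (0.15 log units; within the scatter) from compound 3 to compound 4, at least 10-fold (1.01 log units) apart, beyond the scatter of two such steps

Compound 1 gives > 100000 nM, a limit and not a number, so the earlier step is known only as a bound: the limit of > 100000 nM in this assay, at which 1 of the 4 values shown sits.

These two pairs show that the size of the step differs with the core, but they do not show which feature of the core goes with that difference or how the change would behave on a third core.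

The compounds shown leave open whether the step follows the selenium or the benzyl ring. A benzylsulfanyl or methylselanyl group on the same carbon, on both cores, would separate the two.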